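A Cyclic Amine Replaces the Bridged Diamine

A few compounds are considered here, and "the series" means these few. Any claim that something is new, unique, unknown or untested is made for them only; others in the source may bear on it.

Compound 1 `O=C(CCc1ccc(C(F)(F)F)cc1)Nc1ccc2nc(N3CC4CC3CN4)ccc2c1` has the highest number of the three measured compounds in an assay on isolated protein for displacement of a labelled ligand from melanin-concentrating hormone receptor 1 (Homo sapiens) (on this read-out higher numbers stand for weaker inhibition and lower numbers for stronger inhibition), giving 210 nM. Compound 2 `CCN(CC)c1ccc2cc(NC(=O)CCc3ccc(C(F)(F)F)cc3)ccc2n1` gives 88 nM and compound 3 `O=C(CCc1ccc(C(F)(F)F)cc1)Nc1ccc2nc(N3CC4CC3CO4)ccc2c1` gives 13 nM. Compound 4 `CC1CCCN1c1ccc2cc(NC(=O)CCc3ccc(C(F)(F)F)cc3)ccc2n1` differs from compound 1 in one place: a group of 6 heavy atoms (5 carbon, 1 nitrogen; one five-membered non-aromatic ring with 1 hetero atom) in place of a group of 7 heavy atoms (5 carbon, 2 nitrogen; 2 five-membered non-aromatic rings with 1 hetero atom each), on an aromatic carbon. The nearest measured step swaps the same group for an acyclic amine, a 2.4-fold lower number from compound 1 to compound 2 (0.38 log units; beyond the scatter), while the step to a bicyclic group carrying an oxygen, a 16-fold lower number from compound 1 to compound 3 (1.21 log units; beyond the scatter), was much larger. Compound 2, at 88 nM, carries an amine without the oxygen that marks compound 3, so for compound 4 a modest lowering is expected, a 3.0-fold lower number from compound 1 to compound 4 (0.48 log units; beyond the scatter). For compound 4 the estimate in this assay is 70 nM, within 25 nM to 200 nM.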

Compound 4, half-maximal inhibitory concentration: 5 nM
For compound 4 the middle estimate is 14-fold (1.15 log units) above the measured one; measured number outside the range, below it.
By their numbers in this assay, from the lowest: compound 4; then compound 3; then compound 2; then compound 1.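

In this assay, a single-ring amine suits this position far better than the earlier groups suggested: there is a 42-fold lower number from compound 1 to compound 4 (1.62 log units; beyond the scatter), and replacing diethylamino gives an 18-fold lower number from compound 2 to compound 4 (1.25 log units; beyond the scatter). The oxygen of compound 3 is not required for a low number here: a 2.6-fold lower number from compound 3 to compound 4 (0.41 log units; beyond the scatter) makes compound 4 the lowest of the four, with no oxygen in its group. No measurement shown explains these steps.

As far as these compounds go, it remains open how much depends on the methyl group. Plain pyrrolidin-1-yl or the larger piperidin-1-yl at this position could separate the contribution of the methyl from that of the ring.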